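Phenyl in place of cyclohexyl on the shared core

This account rests on a few compounds, and the source may have more. Where it says the series, first, only, none or still open, it means among the compounds named here.

Measured compounds:
compound 1, `O=S1(=O)N=C(NCC2CCCCC2)Nc2ncccc21`: 145 uM
compound 2, `C[C@H](NC1=NS(=O)(=O)c2cccnc2N1)C1CCCCC1`: > 300 uM, a limit of the assay and not a number
compound 3, `C[C@@H](NC1=NS(=O)(=O)c2cccnc2N1)C1CCCCC1`: > 300 uM, likewise a limit of the assay

Among the compounds with values here, in a functional assay (ileum) for inhibition, with Cavia porcellus as the target (on this read-out lower numbers stand for an effect already at smaller amounts and higher numbers for an effect only at larger amounts of compound), compound 1 stands as the only compound with an actual number; the other two values are limits. The step of an at least 2.0-fold higher number from compound 1 to compound 2 (0.31 log units; beyond the scatter) and the step of an at least 2.0-fold higher number from compound 1 to compound 3 (0.31 log units; beyond the scatter) both follow the same change, methyl in place of hydrogen on a saturated chain carbon bound to an amine nitrogen and a saturated ring carbon. The step that the two limits leave unreadable from compound 2 to compound 3 cannot be sized because of the limit of > 300 uM in this assay, at which 2 of the 3 values shown sit, even though (the fact that compounds 2 and 3 differ only in the configuration as drawn).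

Compound 4, `O=S1(=O)N=C(NCc2ccccc2)Nc2ncccc21`, is not yet measured. It differs from compound 1 by phenyl in place of cyclohexyl on a saturated chain carbon bound to an amine nitrogen. Within the data shown here, none of the measured steps touches this change: they concern the methyl on the chain carbon and the configuration there, not the ring attached to it. Among the measured compounds shown here, with no step bearing on it, compound 4 is estimated to stay near compound 1, so a step of a 1.0-fold higher number from compound 1 to compound 4 (0.01 log units; within the scatter) is expected in this assay, with no direction established beyond the scatter. Compound 4 is therefore estimated at 150 uM, within a range from 50 uM to 400 uM.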

Compound 4, concentration for half-maximal effect: > 300 uM
Compound 4 was reported as a limit; the forecaster's own chance of this, stated with the estimate: 30%; middle value at least 2.0-fold (0.30 log units) from the limit.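

In this assay, the ring itself turns out to matter at this place: phenyl in place of cyclohexyl on a saturated chain carbon bound to an amine nitrogen gives an at least 2.0-fold higher number from compound 1 to compound 4 (0.31 log units; beyond the scatter). Compound 4 gives > 300 uM, which is a limit of the assay and not a number. The earlier compounds had tested only a methyl on the chain carbon and its configuration, whereas this result shows that a change in the ring also moves the read-out beyond the scatter, leaving compound 1 as the only compound with an actual number, and the full size of the step cannot be read because of this: the limit of > 300 uM in this assay, at which 3 of the 4 values shown sit.

The compounds shown leave open whether any other group at this place, such as cyclopentyl, a piperidine ring or a longer chain ending in cyclohexyl, would keep the number of compound 1 or lower it. They also leave open what a substituent on the phenyl, such as a methoxy group or a chlorine atom, would do on the shared core.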